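A few compounds are considered here, and "the series" means these few. Any claim that something is new, unique, unknown or untested is made for them only; others in the source may bear on it.

Measured so far:
- compound 1 `Oc1cccc2[nH]c(-c3ccc(-c4ccc(-c5ccccc5)cc4)cc3)nc12` gives 1110 nM
- compound 2 `Oc1ccc(-c2ccc(-c3ccc(-c4nc5c(O)cccc5[nH]4)cc3)cc2)cc1` gives 190 nM

In a functional assay on Gurav cells (Homo sapiens) for inhibition, read by sulforhodamine B assay (on this read-out lower numbers stand for stronger inhibition of growth and higher numbers for weaker inhibition of growth), compound 2 holds the lower of the two numbers at 190 nM and so shows the stronger inhibition of growth. Compound 3 `COc1ccc(-c2ccc(-c3ccc(-c4nc5c(O)cccc5[nH]4)cc3)cc2)cc1` carries one change from compound 2: methyl in place of hydrogen on an oxygen on an aromatic ring (methyl in place of hydrogen on an oxygen on an aromatic ring, hydroxy to methoxy). Among the compounds with values here, the only measured step is a 5.8-fold lower number from compound 1 to compound 2 (0.77 log units; beyond the scatter) for hydroxy in place of hydrogen on an aromatic carbon, and it lies beyond the scatter. Within the data shown here, that hydroxy is the group now changed, though no measured step covers methoxy itself. Part of that gain is expected to be lost, so a higher number is expected, with a rise smaller than the measured step. The expected step in this assay is a 2.1-fold higher number from compound 2 to compound 3 (0.32 log units; beyond the scatter) as an estimate. Compound 3 is estimated at 400 nM with an expected range from 130 nM to 1000 nM in this series.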

Compound 3, concentration for 50% growth inhibition: 6630 nM
Beside the measured number, compound 3's estimate is 17-fold (1.22 log units) below it; the whole stated range lies below it.
By their numbers in this assay, from the lowest: compound 2; then compound 1; then compound 3.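

In this assay, methyl in place of hydrogen on the oxygen of the 4-hydroxyphenyl group does more than undo the earlier gain: the step (a 35-fold higher number from compound 2 to compound 3 (1.54 log units; beyond the scatter)) is larger than the one that hydroxy brought (a 5.8-fold lower number from compound 1 to compound 2 (0.77 log units; beyond the scatter)). Methoxy also ends up worse than plain hydrogen at this place (a 6.0-fold higher number from compound 1 to compound 3 (0.78 log units; beyond the scatter)), so the oxygen alone does not preserve the gain, and the free hydroxy is the form linked to the lowest number here. This position therefore responds in both directions, with hydroxy, hydrogen and methoxy in that order from the lowest number.

No measurement available here explains the size of this loss. Still open, as far as these compounds go, is whether a longer chain on the oxygen, such as ethoxy, goes further the same way, and whether an amine or a carboxylic acid in place of the hydroxy holds the level of compound 2.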